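The compounds below may be only part of what the source reports. "The series", "measured", "known", "first", "only" and "open" are said of these compounds alone.

In a functional assay on NCI-H460 cells (Homo sapiens) for inhibition, read by sulforhodamine B assay, with a stated time of 48 h (on this read-out higher numbers stand for weaker inhibition of growth and lower numbers for stronger inhibition of growth), compound 1 `CCOC(=O)C1=C(C)NC(=O)NC1c1ccc(SC)cc1` gives 3.6 ug/mL and compound 2 `CCOC(=O)C1=C(C)NC(=S)NC1C1CCCCC1` gives 3.5 ug/mL. Compound 3 `CCOC(=O)C1=C(C)NC(=S)NC1c1ccc(O)cc1` reaches only a limit of this assay, > 250 ug/mL, a value that stands at the limit of > 250 ug/mL in this assay, at which 1 of the 3 values shown sits. Compound 4 `CCOC(=O)C1=C(C)NC(=S)NC1c1ccc(O)c(O)c1` differs from compound 3 by a single change, (hydroxy in place of hydrogen on an aromatic carbon), a hydroxy in place of hydrogen on an aromatic carbon. Among the compounds with values here, no measured pair shows a step of this kind, so what the second hydroxy does to growth inhibition in this assay cannot be read from the three values shown. Compound 4 is expected to stay close to the limit, with an estimated step of a number no higher from compound 3 to compound 4 (the limit leaves the size open) that should not clearly exceed the usual scatter. For compound 4 the estimate in this assay is 250 ug/mL, with a range from 60 ug/mL to 1000 ug/mL.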

Compound 4, concentration for 50% growth inhibition: 31.7 ug/mL
For compound 4 the middle estimate is 7.9-fold (0.90 log units) above the measured one, outside the stated range (below it).
By their numbers in this assay, from the lowest: compounds 2 and 1 (each within the scatter of the next); then compound 4. At a limit, above all of these: compound 3.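

In this assay, within the data shown here, this is the first measured step at a single place: a hydroxy in place of hydrogen on an aromatic carbon, ortho to a hydroxy group and meta to a large group, gives an at least 7.8-fold lower number from compound 3 to compound 4 (0.89 log units; beyond the scatter). The added hydroxy therefore goes with clearly stronger inhibition of growth, so this position is not silent. Compound 3 stands at a limit and not at a number, so the full size of the step stays open: the limit of > 250 ug/mL in this assay, at which 1 of the 4 values shown sits.

The compounds shown leave open what a methoxy or an amine on this same carbon would do. They also leave open whether this hydroxy gives a similar step when no other hydroxy stands on the ring.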